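A few compounds are considered here, and "the series" means these few. Any claim that something is new, unique, unknown or untested is made for them only; others in the source may bear on it.

Compound 1 `Nc1ccccc1NC(=O)c1ccc(CSC(=S)N2CCN(c3ccccc3)CC2)cc1`: 2140 nM
Compound 2 `Nc1ccccc1NC(=O)c1ccc(CSC(=S)N2CCc3ccccc32)cc1`: 2300 nM
Compound 3 `Nc1ccccc1NC(=O)c1ccc(CSC(=S)N2CCN(c3ccc(F)cc3)CC2)cc1`: 17200 nM

All three values come from a functional assay on MGC-803 cells (Homo sapiens) for antiproliferative activity, read by CCK-8 assay, with a stated time of 72 h; a higher number here means a weaker inhibitor, a lower number a stronger inhibitor. Compound 2 lies within the scatter of compound 1, and compound 3 stands beyond the scatter of both with the highest number. Compound 4 `CC1CCCCN1C(=S)SCc1ccc(C(=O)Nc2ccccc2N)cc1` carries 2-methylpiperidin-1-yl in place of 2,3-dihydro-1H-indol-1-yl on a thiocarbonyl carbon. Within the data shown here, the only measured step, an 8.0-fold higher number from compound 1 to compound 3 (0.91 log units; beyond the scatter), is fluoro in place of hydrogen on an aromatic carbon. It is modest and does not make this exchange. The groups on the thiocarbonyl carbon differ between compound 1 and compound 2, yet compound 1 at 2140 nM and compound 2 at 2300 nM sit within the scatter. No step beyond the scatter is therefore expected in this assay, and no firm direction. The estimated change is a 1.3-fold higher number from compound 2 to compound 4 (0.12 log units; within the scatter). Compound 4 is expected at 3000 nM, with an estimated range from 800 nM to 12000 nM.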

Compound 4, half-maximal inhibitory concentration: 1610 nM
Compound 4: middle estimate off by 1.9-fold (0.27 log units), on the high side; the range from low to high includes it.
By their numbers in this assay, from the lowest: compounds 4, 1 and 2 (each within the scatter of the next); then compound 3.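

In this assay the exchange on the thiocarbonyl carbon gives a 1.4-fold lower number from compound 2 to compound 4 (0.15 log units; within the scatter) and no shift beyond the scatter. The fused aromatic ring of 2,3-dihydro-1H-indol-1-yl is therefore not needed at this position to keep this level of activity, since 2-methylpiperidin-1-yl has only a non-aromatic ring. No measurement at hand explains this tolerance. Still open, on these data alone, is whether morpholine or unsubstituted piperidine on the thiocarbonyl carbon would hold the same level. As far as these compounds go, the contribution of the methyl group of 2-methylpiperidin-1-yl also remains open.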